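Adding a Third Methoxy Group to Compound 2

The source may hold more compounds than are shown below. What is called first, only, known or untested is meant among the compounds shown, and "the series" means these compounds.

Three compounds have been measured in a functional assay on MDA-MB-231 cells (Homo sapiens) for inhibition, read by sulforhodamine B assay, with a stated time of 48 h; a lower number here means a stronger inhibitor of growth, a higher number a weaker inhibitor of growth:
Compound 1 `Nc1cc(N)c2nc(-c3ccccc3)c(NCc3ccc(Cl)c(Cl)c3)nc2c1` gives 1580 nM in this assay.
Compound 2 `COc1ccc(CNc2nc3cc(N)cc(N)c3nc2-c2ccccc2)cc1OC` gives 11200 nM in this assay.
Compound 3 `CCOC(=O)[C@H](CCC(=O)O)NC(=O)c1ccc(Sc2nc3cc(N)cc(N)c3nc2-c2ccccc2)cc1` gives 7940 nM in this assay.

Compound 2 has the highest number of the three, though its gap to compound 3 lies within the usual scatter; only the gap to compound 1 is clearly beyond it, as the step of a 7.1-fold higher number from compound 1 to compound 2 (0.85 log units; beyond the scatter) shows. Going by the values given here, that step, swapping the two chlorines for two methoxy groups on the ring carried by the saturated chain carbon, is the single measured change near the one now considered.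

Compound 4 `COc1cc(CNc2nc3cc(N)cc(N)c3nc2-c2ccccc2)cc(OC)c1OC` differs from compound 2 by methoxy in place of hydrogen on an aromatic carbon. Among the compounds with values here, no measured pair adds a third methoxy group to an already twice-methoxylated ring, so the only guide is that moving toward methoxy groups so far went with a higher number. A small step upward, or none beyond the scatter, is expected in this assay, giving a 1.3-fold higher number from compound 2 to compound 4 (0.13 log units; within the scatter). Compound 4 is therefore estimated at 15000 nM, within a range from 6000 nM to 40000 nM.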

Compound 4, concentration for 50% growth inhibition: 7240 nM
Compound 4: middle estimate off by 2.1-fold (0.32 log units), on the high side; the measured number falls inside the stated range.
By their numbers in this assay, from the lowest: compound 1; then compounds 4, 3 and 2 (each within the scatter of the next).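

In this assay, methoxy in place of hydrogen on this aromatic carbon, ortho to a methoxy group, goes with a 1.5-fold lower number from compound 2 to compound 4 (0.19 log units; within the scatter), so compound 2 and compound 4 cannot be told apart. The earlier change on this ring, a 7.1-fold higher number from compound 1 to compound 2 (0.85 log units; beyond the scatter), lay beyond the scatter, whereas this one shows that a further change on the same ring need not shift the number measurably. No measurement at hand offers an explanation for this result.

On these data alone, it remains open whether a hydroxyl group or a longer ethoxy group on this same carbon would also leave the number within the scatter. Going by these compounds alone, it is equally open whether the ring needs all its methoxy groups, as no compound here carries a single one.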